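Primary-oxygen group variation in a nitrophenyl oxadiazole glycoside series

This account rests on a few compounds, and the source may have more. Where it says the series, first, only, none or still open, it means among the compounds named here.

Measured compounds:
Compound 1 `Nc1nnc(SC[C@H]2O[C@@H](OCc3noc(-c4ccc([N+](=O)[O-])cc4)n3)[C@@H]3OC4(CCCC4)O[C@@H]32)s1` gives 26000 nM in a functional assay on HBL-100 cells (Homo sapiens) for antiproliferative activity, read by sulforhodamine B assay, with a stated time of 48 h; a lower number here means a stronger inhibitor of growth, a higher number a weaker inhibitor of growth.
Compound 2 `CC(=O)OC[C@H]1O[C@@H](OCc2noc(-c3ccc([N+](=O)[O-])cc3)n2)[C@@H]2OC3(CCCC3)O[C@@H]21` gives 23000 nM in this assay.

Within the data shown here, compound 2 holds the lower of the two numbers measured so far, but the gap to compound 1 is small: a 1.1-fold lower number from compound 1 to compound 2 (0.05 log units; within the scatter). On these numbers the two compounds cannot be told apart, and neither may be called the stronger inhibitor.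

The next compound, compound 3 `Cc1ccc(S(=O)(=O)OC[C@H]2O[C@@H](OCc3noc(-c4ccc([N+](=O)[O-])cc4)n3)[C@@H]3OC4(CCCC4)O[C@@H]32)cc1`, differs from compound 2 in one place: (4-methylphenyl)sulfonyl in place of acetyl on an oxygen on a saturated carbon. Among the measured compounds shown here, the one measured step that bears on this position is the exchange at the same saturated chain carbon, a 1.1-fold lower number from compound 1 to compound 2 (0.05 log units; within the scatter), where two quite different groups gave numbers within the scatter of each other. For the measured compounds named here, with only that step to go on, a change of group on the oxygen of the same chain carbon is expected to leave the number where it is, with no step beyond the scatter in either direction.

Compound 3 is therefore expected to give 20000 nM in this assay, with a range of 7000 nM to 55000 nM. The expected step is a 1.2-fold lower number from compound 2 to compound 3 (0.06 log units; within the scatter).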

Compound 3, concentration for 50% growth inhibition: > 100000 nM
Compound 3 was reported as a limit; the forecaster's own chance of this, stated with the estimate: 15%; middle value at least 5.0-fold (0.69 log units) away from the limit.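

In this assay compound 3 is reported only as a limit, not as a number: the limit of > 100000 nM in this assay, at which 1 of the 3 values shown sits.

This position is therefore not indifferent to the group it carries: the change gives an at least 4.3-fold higher number from compound 2 to compound 3 (0.63 log units; beyond the scatter), and the exchange against the thiadiazole compound gives an at least 3.8-fold higher number from compound 1 to compound 3 (0.58 log units; beyond the scatter), both readable as steps even though one end of each is a limit, whereas the earlier exchange gave a 1.1-fold lower number from compound 1 to compound 2 (0.05 log units; within the scatter). Among these compounds, the flat picture from the first two compounds thus holds only for the acetoxy and (5-amino-1,3,4-thiadiazol-2-yl)sulfanyl groups, and ((4-methylphenyl)sulfonyl)oxy is the one group of the three that separates from the others, by a size that stays open-ended.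

Whether the sulfonyl link or the aromatic ring of the entering group accounts for the step stays open; a methylsulfonyl or a benzoyl group on the same oxygen would separate the two. Also open, going by these compounds, is whether a free hydroxyl or an amine on the same saturated chain carbon would sit with compound 1 and compound 2 or with compound 3.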